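The source may report more compounds than this note shows. Statements on the series, on what has been measured and on what is new or still open speak of the compounds shown alone.

Compound 1 `CC/C=C\C/C=C\C/C=C\CCCCCCCC1(O)CC(=O)c2c(O)cc(OCOC)cc2O1` and compound 2 `CCCCC/C=C\C/C=C\CCCCCCCC1(O)CC(=O)c2c(O)cc(OCOC)cc2O1` share one core, while compound 3 `CCCCC/C=C\C/C=C\CCCCCCCc1cc(=O)c2c(O)c(C)c(OCOC)cc2o1` and compound 4 `CC/C=C\C/C=C\C/C=C\CCCCCCCc1cc(=O)c2c(O)c(C)c(OCOC)cc2o1` share another; the difference between the two cores is not broken down here. In a functional assay on MCF7 cells (Homo sapiens) for antiproliferative activity, read by MTT assay (a lower number here means a stronger inhibitor, a higher number a weaker inhibitor), compound 1 gives 17500 nM. For compound 2 the reading is only a limit, > 84100 nM, which is the limit of > 84100 nM in this assay, at which 1 of the 3 values shown sits. The step of an at least 4.8-fold lower number from compound 2 to compound 1 (0.68 log units; beyond the scatter) goes with the change (but-1-en-1-yl in place of butyl on a saturated chain carbon bound to a double-bonded chain carbon). For compound 3 the reading is likewise only a limit, > 67200 nM, which is the limit of > 67200 nM in this assay, at which 1 of the 3 values shown sits. Compound 4 carries the same change on the core of compound 3, namely (but-1-en-1-yl in place of butyl on a saturated chain carbon bound to a double-bonded chain carbon). Because the measured step of an at least 4.8-fold lower number from compound 2 to compound 1 (0.68 log units; beyond the scatter) was at least modest and points in one direction, the step from compound 3 to compound 4 is expected to be an at least 3.3-fold lower number from compound 3 to compound 4 (0.52 log units; beyond the scatter), though the starting value of compound 3 being a limit leaves the size open. Compound 4 is thus estimated at 20000 nM in this assay, expected to fall between 7000 nM and 70000 nM.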

Compound 4, half-maximal inhibitory concentration: 17500 nM
The estimate for compound 4 lay 1.1-fold (0.06 log units) above the measured number, within the range that was stated.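

In this assay, but-1-en-1-yl in place of butyl on a saturated chain carbon bound to a double-bonded chain carbon gives an at least 3.8-fold lower number from compound 3 to compound 4 (0.58 log units; beyond the scatter), and the change points the same way on both cores: the same change on two cores in this assay, an at least 4.8-fold lower number (0.68 log units; beyond the scatter) from compound 2 to compound 1 and an at least 3.8-fold lower number (0.58 log units; beyond the scatter) from compound 3 to compound 4; the limit leaves it open whether they differ

The reading for compound 3 is only a limit of the assay, > 67200 nM. With a limit at the start of both steps, the two pairs show a shared direction but no shared size, and they show nothing about this change on any other core.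

The compounds shown leave open how a shorter chain, a longer chain or a chain ending in a carboxylic acid would read in this assay, since every chain here is one of two unsaturated hydrocarbon chains. Also open, going by these compounds, is how either core would read with a free hydroxyl in place of the methoxymethoxy group, which all four compounds carry.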